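A few compounds are considered here, and "the series" means these few. Any claim that something is new, unique, unknown or untested is made for them only; others in the source may bear on it.

Compound 1 `CN1CCN(C(=S)SSC(=S)N2CCN(C)CC2)CC1` and compound 2 `CCCCSSC(=S)N(CC)CC` have both been tested in an ADME assay on MCF-10A cells (Homo sapiens) for antiproliferative activity, read by MTT assay, with a stated time of 72 h; a higher number here means a weaker inhibitor, a lower number a stronger inhibitor. For compound 1 the assay gives only its limit, > 10000 nM, not a measured number. Compound 2 likewise reaches only the limit, > 10000 nM, so no number is known for it either. Compound 2 thus stands at the edge of what this assay can report, and it shares that position with the only other compound shown: the limit of > 10000 nM in this assay, at which 2 of the 2 values shown sit.

Compound 3 `CCN(CC)C(=S)SSC(C)C` has not yet been measured in this assay. Its structure differs from that of compound 2 in one place: isopropyl in place of butyl on a sulfur. Going by the values given here, no measured step between two compounds is available here, so there is nothing to show how a change of this kind moves the number in this assay. With both known values sitting at the limit, a step that stays within the usual scatter, in no particular direction, is expected. The step expected is a step that the limit leaves unreadable from compound 2 to compound 3. Compound 3 is therefore estimated at 15000 nM, with a range from 7000 nM to 40000 nM, and the assay is expected most likely to report only its limit again.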

Compound 3, half-maximal inhibitory concentration: > 10000 nM
Compound 3: a limit, no number; the forecaster's own chance of this, stated with the estimate: 85%; the middle value lies beyond the limit too.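

In this assay compound 3 gives only a limit of > 10000 nM and no number. Going by these compounds alone, no step from compound 2 to compound 3 can be read, because both sit at the same limit: the limit of > 10000 nM in this assay, at which 3 of the 3 values shown sit. The compounds shown leave open how strongly any of them acts on these cells, and whether changing the group on the sulfur moves that number at all.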